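The source may report more compounds than this note shows. Statements on the series, on what has been measured and on what is new or still open speak of the compounds shown alone.

Compound 1 `NCC1CCN(c2c(F)cc3c(=O)c(C(=O)O)cn(C4CC4)c3c2F)C1`: 11 ug/mL
Compound 2 `CNCC1(C)CCN(c2c(F)cc3c(=O)c(C(=O)O)cn(C4CC4)c3c2F)C1`: 8 ug/mL

Both compounds were tested in a functional assay on V79 cells (Cricetulus griseus) for cytotoxicity, read by colony formation; a higher number here means a weaker inhibitor, a lower number a stronger inhibitor. Compound 1 gives 11 ug/mL and compound 2 gives 8 ug/mL; the step of a 1.4-fold lower number from compound 1 to compound 2 (0.14 log units; within the scatter) is within the scatter, so the two numbers cannot be told apart, and compound 2 stands alongside compound 1 rather than apart from it. Compound 3 `CC1CN(c2c(F)cc3c(=O)c(C(=O)O)cn(C4CC4)c3c2F)CC(C)N1` is not yet measured. It differs from compound 2 in one place: 3,5-dimethylpiperazin-1-yl in place of 3-methyl-3-((methylamino)methyl)pyrrolidin-1-yl on an aromatic carbon. For the measured compounds named here, the only measured step, from compound 1 to compound 2, also swapped the group on this aromatic carbon and gave a 1.4-fold lower number from compound 1 to compound 2 (0.14 log units; within the scatter), a change within the scatter. Going by the values given here, no measured step covers a piperazine in this position, so the expectation rests on that single step alone. On that basis the step of a 1.3-fold higher number from compound 2 to compound 3 (0.10 log units; within the scatter) is expected to stay within the scatter. Compound 3 is therefore estimated at 10 ug/mL, with a range from 4 ug/mL to 25 ug/mL.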

Compound 3, half-maximal inhibitory concentration: 150 ug/mL
Compound 3: the middle estimate sits 15-fold (1.18 log units) below what was measured; the whole stated range lies below it.
By their numbers in this assay, from the lowest: compounds 2 and 1 (each within the scatter of the next); then compound 3.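

At this position on the aromatic carbon, ortho to two fluoro groups, the choice of group can move the result sharply: in this assay, 3,5-dimethylpiperazin-1-yl gives a 19-fold higher number from compound 2 to compound 3 (1.27 log units; beyond the scatter) and, in place of 3-(aminomethyl)pyrrolidin-1-yl, gives a 14-fold higher number from compound 1 to compound 3 (1.13 log units; beyond the scatter) as well. The two pyrrolidine groups of compound 1 and compound 2 stood within the scatter of each other, so they gave no sign that a swap here could reach so far, and compound 3 now marks the weak end of this small set. Nothing in the data at hand explains this jump.

On these data alone, what stays open is whether the six-membered ring or its two methyl groups goes with the higher number. A plain piperazin-1-yl group, carrying neither methyl, would separate those two parts of the change.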